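Swapping a Ring Substituent in a Cytotoxicity Series

The compounds below may be only part of what the source reports. "The series", "measured", "known", "first", "only" and "open" are said of these compounds alone.

Two measured compounds share a common core. Compound 1, `Fc1cc(Nc2cc(Nc3ccc(Cl)cc3)ncn2)ccc1Oc1ccncc1-c1cccnc1`, and compound 2, `Cn1c(=O)c(C(=O)Nc2ccc(Oc3ccncc3-c3cccnc3)c(F)c2)nn(-c2ccc(Cl)cc2)c1=O`, have both been tested in a functional assay on A549 cells (Homo sapiens) for cytotoxicity, read by MTT assay, with a stated time of 72 h; a lower number here means a stronger inhibitor, a higher number a weaker inhibitor. In this assay compound 1 gives 1610 nM. In this assay compound 2 gives 930 nM, the lowest of the two numbers, although the gap to compound 1 lies within the usual scatter, so no real order between the two can be claimed.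

Compound 3, `COc1ccc(-n2nc(C(=O)Nc3ccc(Oc4ccncc4-c4cccnc4)c(F)c3)c(=O)n(C)c2=O)c(OC)c1`, has not yet been measured. It differs from compound 2 in a single place: 2,4-dimethoxyphenyl in place of 4-chlorophenyl on an aromatic nitrogen. For the measured compounds named here, no pair of measured compounds shows what such a change does, and nothing measured so far tells how a change at this position moves the number. The expectation is therefore a small step in this assay, in no firm direction, quite possibly none beyond the scatter. For compound 3 the estimate in this assay is 1200 nM, with a range from 400 nM to 4000 nM. That estimate means an expected step of a 1.3-fold higher number from compound 2 to compound 3 (0.11 log units; within the scatter), a slight weakening that could easily disappear on repeat measurement.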

Compound 3, half-maximal inhibitory concentration: 890 nM
Beside the measured number, compound 3's estimate is 1.3-fold (0.13 log units) above it; the range from low to high includes it.
By their numbers in this assay, from the lowest: compounds 3, 2 and 1 (each within the scatter of the next).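

For the compounds shown here, this is the first measured pair that differs only in the group on the aromatic nitrogen, and in this assay it gives a 1.0-fold lower number from compound 2 to compound 3 (0.02 log units; within the scatter), a step within the usual scatter. At this position, then, 4-chlorophenyl with 7 heavy atoms and 2,4-dimethoxyphenyl with 10 heavy atoms give numbers that cannot be told apart, even though the swap removes the chlorine and adds 2 hydrogen-bond acceptors. No supporting evidence is available to explain this result, so it remains a plain observation about a single pair of compounds.

Both groups compared here are substituted phenyl rings, so the pair says nothing about how a different kind of group would behave at this position, such as a plain methyl, a longer alkyl chain, or a phenyl ring carrying an amine or a carboxylic acid. Going by these compounds alone, it also leaves open what a phenyl ring with only one methoxy group would give, and so whether each of the two methoxy groups matters on its own.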